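This account rests on a few compounds, and the source may have more. Where it says the series, first, only, none or still open, it means among the compounds named here.

Measured compounds:

compound 1, `Cc1cc(C(=O)O)c(C)n1-c1cccc(F)c1` — 1500 nM
compound 2, `Cc1cc(C(=O)O)c(C)n1-c1cccc(Cl)c1` — 430 nM
compound 3, `Cc1cc(C(=O)O)c(C)n1-c1cccc(Cl)c1Cl` — 220 nM

All three share one core and were tested in an assay on cells for inhibition of Palmitoleoyl-protein carboxylesterase NOTUM variant C330S (Homo sapiens), read by fluorescence, with a stated time of 40 min; on this read-out higher numbers stand for weaker inhibition and lower numbers for stronger inhibition. Compound 2 gives 430 nM in this assay, and compound 1 gives 1500 nM. The two differ in one place, (fluoro in place of chloro on an aromatic carbon), and that change gave a 3.5-fold higher number from compound 2 to compound 1 (0.54 log units; beyond the scatter), a step beyond the usual scatter. Compound 3 differs from compound 2 by chloro in place of hydrogen on an aromatic carbon; this gave a 2.0-fold lower number from compound 2 to compound 3 (0.29 log units; within the scatter), which stays within the scatter, so compound 3 and compound 2 cannot be ranked against each other on this evidence. Against compound 1, however, compound 3 stands apart by a gap beyond the scatter.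

Compound 4, `Cc1cc(C(=O)O)c(C)n1-c1cccc(Cl)c1F`, has not yet been measured in this assay. It differs from compound 3 by fluoro in place of chloro on an aromatic carbon. Among the measured compounds shown here, this is the same kind of change as the one from compound 2 to compound 1, but the place is not the same: in compound 1 the fluoro sits meta to a large group, whereas in compound 4 it sits ortho to a chloro group and ortho to a large group. Because the step of a 3.5-fold higher number from compound 2 to compound 1 (0.54 log units; beyond the scatter) was seen for the earlier occurrence of this change, a step of similar direction is expected here, and the expected step from compound 3 to compound 4 is a 3.0-fold higher number from compound 3 to compound 4 (0.47 log units; beyond the scatter). For the measured compounds named here, with only one prior example at a different place, the estimate is held loosely. Compound 4 is therefore expected to give about 650 nM in this assay, most likely between 250 nM and 1700 nM.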

Compound 4, half-maximal inhibitory concentration: 380 nM
For compound 4 the middle estimate is 1.7-fold (0.23 log units) above the measured one; the measured number falls inside the stated range.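

Fluoro in place of chloro, on an aromatic carbon ortho to a chloro group and ortho to a large group, gave a 1.7-fold higher number from compound 3 to compound 4 (0.24 log units; within the scatter), so compound 3 and compound 4 cannot be ranked against each other, and fluoro in place of hydrogen on that same carbon gave a 1.1-fold lower number from compound 2 to compound 4 (0.05 log units; within the scatter), which leaves compound 2 and compound 4 unranked as well. Set beside the earlier case, the two steps of this one change cannot be told apart: the same change on two cores in this assay, a 3.5-fold higher number (0.54 log units; beyond the scatter) from compound 2 to compound 1 and a 1.7-fold higher number (0.24 log units; within the scatter) from compound 3 to compound 4, 2.0-fold (0.31 log units) apart, within the scatter of two such steps The two results are therefore compatible with a single size for this change across the two cores, but they do not establish that it carries over unchanged, as this rests on only two pairs, with the change at a different place on the ring in each and with only one of the two steps beyond the scatter.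

The compounds shown leave open what a bromo, methoxy or nitrile group would give at these same places on the ring. They also leave open how the numbers would move if an amide took the place of the carboxylic acid on the shared core.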